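The compounds below may be only part of what the source reports. "The series", "measured", "known", "first", "only" and "open" are said of these compounds alone.

Measured so far in a physicochemical assay for solubility, in phosphate buffer, at pH 7.4; a higher number here means a more soluble compound, a lower number a less soluble compound:
Compound 1 `CN(C)C(=O)CN1CCC(c2cc3c(-c4ccc(=O)n(C)c4)ccnc3[nH]2)CC1` gives > 1000000 nM, which is a limit of the assay and not a number (the limit of > 1000000 nM in this assay, at which 1 of the 3 values shown sits).
Compound 2 `CN(C)C(=O)CN1CCC(c2cc3c(-c4ccc(=O)n(C5CCOCC5)c4)ccnc3[nH]2)CC1` gives 840000 nM.
Compound 3 `COc1cc(F)ccc1-c1ccnc2[nH]c(C3CCN(CC(=O)N(C)C)CC3)cc12` gives 38000 nM.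

Compound 3 holds the lowest of the two numbers in this assay; the nearest is compound 2, with an at least 26-fold lower number from compound 1 to compound 3 (1.42 log units; beyond the scatter) the measured step leading away from the shared core with the pyridone ring. Compound 4 `CCn1cc(-c2ccnc3[nH]c(C4CCN(CC(=O)N(C)C)CC4)cc23)ccc1=O` carries a group of 9 heavy atoms (7 carbon, 1 nitrogen, 1 oxygen; one six-membered aromatic ring with 1 hetero atom) in place of a group of 9 heavy atoms (7 carbon, 1 oxygen, 1 fluorine; one six-membered aromatic ring of carbon only), on an aromatic carbon. This reverses the change seen in an at least 26-fold lower number from compound 1 to compound 3 (1.42 log units; beyond the scatter), a large step, with an ethyl rather than a methyl on the ring nitrogen; an at least 1.1-fold lower number from compound 1 to compound 2 (0.07 log units; that floor lies within the scatter) shows that the group on that nitrogen moves the number little. A large rise in this assay is therefore expected from compound 3 to compound 4, an 18-fold higher number from compound 3 to compound 4 (1.27 log units; beyond the scatter). Compound 4 is estimated at 700000 nM, between 200000 nM and 2000000 nM.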

Compound 4, solubility: > 1000000 nM
Compound 4: a limit, no number; the forecaster's own chance of this, stated with the estimate: 40%; middle value at least 1.4-fold (0.15 log units) from the limit.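

Replacing 4-fluoro-2-methoxyphenyl on the aromatic carbon opposite the ring nitrogen gives an at least 26-fold higher number from compound 3 to compound 4 (1.42 log units; beyond the scatter) in this assay, so the large gap seen with methyl on the aromatic nitrogen also holds with ethyl there. Ethyl in place of oxan-4-yl on that nitrogen gives an at least 1.1-fold higher number from compound 2 to compound 4 (0.07 log units; that floor lies within the scatter), and the step from compound 1 to compound 4 cannot be read. Compound 4 gives a limit of the assay, not a number: the limit of > 1000000 nM in this assay, at which 2 of the 4 values shown sit.

Any order among ethyl, methyl and oxan-4-yl on that nitrogen stays open. Also open, going by these compounds, is how a phenyl carrying an amine or a carboxylic acid would read at this aromatic carbon in this assay.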